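The compounds below may be only part of what the source reports. "The series", "measured", "known", "first", "only" and "open" are said of these compounds alone.

Measured in a functional assay on SK-OV-3 cells (Homo sapiens) for antiproliferative activity, read by MTT assay, with a stated time of 24 h; a higher number here means a weaker inhibitor, a lower number a stronger inhibitor:
- compound 1 `COc1ccc(C(=O)/C=C/c2ccc(N3CCCC3)cc2)c2c1C=CC(C)(C)O2`: 7370 nM
- compound 2 `COc1ccc(C(=O)/C=C/c2cccc([N+](=O)[O-])c2)c2c1C=CC(C)(C)O2`: 9720 nM
- compound 3 `COc1ccc(C(=O)/C=C/c2ccccn2)c2c1C=CC(C)(C)O2`: 8390 nM

The three numbers lie close together. Compound 3, at 8390 nM, sits with the other two inside the usual scatter, so this assay does not separate it from either of them.

The next compound is compound 4 `COc1ccc(C(=O)/C=C/c2ccc(O)cc2)c2c1C=CC(C)(C)O2`, which keeps the shared core and has 4-hydroxyphenyl in place of pyridin-2-yl on a double-bonded chain carbon bound to a double-bonded chain carbon.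

For the measured compounds named here, only one measured step touches this place, and it is a 1.2-fold lower number from compound 2 to compound 3 (0.06 log units; within the scatter). That exchange of one aromatic group for another left the number within the scatter. Compound 1 carries yet another group at the same place and gives 7370 nM, which is again close to the others. Going by the values given here, none of the measured compounds carries a 4-hydroxyphenyl group, so the data cannot rule out a larger shift, and the range is kept wide.

On this evidence no change beyond the scatter is expected, and no direction is favoured. The expected step is a 1.0-fold lower number from compound 3 to compound 4 (0.02 log units; within the scatter). For compound 4 the estimated value is 8000 nM, with an expected range from 3500 nM to 16000 nM.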

Compound 4, half-maximal inhibitory concentration: > 10000 nM
Compound 4 gave a limit, no number; the forecaster's own chance of this, stated with the estimate: 5%; at least 1.2-fold (0.09 log units) between middle value and limit.
By their numbers in this assay, from the lowest: compounds 1, 3 and 2 (each within the scatter of the next). At a limit, above all of these: compound 4.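

In this assay, compound 4 gives a limit and not a number, the only one of the four compounds to do so: the limit of > 10000 nM in this assay, at which 1 of the 4 values shown sits.

Read against that limit, the steps are an at least 1.1-fold higher number from compound 3 to compound 4 (0.07 log units; that floor lies within the scatter), an at least 1.0-fold higher number from compound 2 to compound 4 (0.01 log units; that floor lies within the scatter) and an at least 1.3-fold higher number from compound 1 to compound 4 (0.13 log units; that floor lies within the scatter), so each floor stays inside the scatter and the result does not separate compound 4 from the other three. What it adds is limited but new: the earlier groups at this place, on a double-bonded chain carbon bound to a double-bonded chain carbon, all gave numbers, whereas 4-hydroxyphenyl, which brings a hydrogen-bond donor that pyridin-2-yl lacks, gives only a lower bound, and that bound leaves room for a true value close to the others or far from them.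

The compounds shown leave open how far beyond its limit compound 4 really lies, so the true size of all three steps remains unknown. They also leave open whether the hydroxy group itself matters, which a methoxy group or a primary amine in place of hydroxy on an aromatic carbon would help to settle.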